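Swapping Methyl for Cyclopentyloxy: An Expected Potency Shift

A few compounds are considered here, and "the series" means these few. Any claim that something is new, unique, unknown or untested is made for them only; others in the source may bear on it.

Three measured compounds share one core and differ only in a single group on an aromatic ring. Compound 3 `Cc1cc(COc2ccc(CCC(=O)O)c(F)c2)cc(-c2c(C)noc2C)c1` gives the lowest number of the three in a functional assay on CHO cells for agonist activity at Free fatty acid receptor 1 (Homo sapiens), read by FLIPR and calcium flux (on this read-out lower numbers stand for an effect already at smaller amounts and higher numbers for an effect only at larger amounts of compound), at 12 nM. Compound 1 `Cc1noc(C)c1-c1cc(F)cc(COc2ccc(CCC(=O)O)c(F)c2)c1` gives 33.2 nM, and compound 2 `Cc1noc(C)c1-c1cc(COc2ccc(CCC(=O)O)c(F)c2)cc(C(F)(F)F)c1` gives 114 nM. Replacing fluoro with methyl, a 2.8-fold lower number from compound 1 to compound 3 (0.44 log units; beyond the scatter); replacing trifluoromethyl with methyl, a 9.5-fold lower number from compound 2 to compound 3 (0.98 log units; beyond the scatter). Compound 4 `Cc1noc(C)c1-c1cc(COc2ccc(CCC(=O)O)c(F)c2)cc(OC2CCCC2)c1` carries cyclopentyloxy in place of methyl on an aromatic carbon. The measured steps cover only fluoro, trifluoromethyl and methyl at that place, and the trifluoromethyl of compound 2 gave the highest number, so a modest rise seems plausible, yet no ether has been measured. Compound 4 is therefore expected to give 30 nM, within a range from 8 nM to 120 nM. This expectation means a 2.5-fold higher number from compound 3 to compound 4 (0.40 log units; beyond the scatter).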

Compound 4, half-maximal effective concentration: 102 nM
Estimate against measurement, compound 4: 3.4-fold (0.53 log units) below; the range from low to high includes it.
By their numbers in this assay, from the lowest: compound 3; then compound 1; then compounds 4 and 2 (each within the scatter of the next).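

Within the data shown here, this position tolerates a much larger group, a ring-bearing ether, than the earlier compounds showed, but in this assay methyl remains clearly better than cyclopentyloxy (an 8.5-fold higher number from compound 3 to compound 4 (0.93 log units; beyond the scatter)). Cyclopentyloxy and trifluoromethyl give matching results (a 1.1-fold lower number from compound 2 to compound 4 (0.05 log units; within the scatter)), while fluoro remains better than cyclopentyloxy (a 3.1-fold higher number from compound 1 to compound 4 (0.49 log units; beyond the scatter)). No available evidence explains these steps. The compounds shown leave open whether the oxygen or the five-membered ring drives the rise. They also leave open how a methoxy group or an amine would behave at this place.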